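The source may hold more compounds than are shown below. What is called first, only, known or untested is meant among the compounds shown, and "the series" means these compounds.

Compound 2, `Fc1cccc(N2CCN(CCCOc3ccc4c(c3)CCC4)CC2)c1`, is the starting point here. Among the compounds with values here, in a functional assay on the whole organism for inhibition, with Mus musculus as the target, at a dose of 25 mg/kg by the oral route (on this read-out lower numbers stand for less inhibition and higher numbers for more inhibition at the one dose given (going by the name of the read-out)), compound 2 gives 19%, the second highest of the three numbers known. Compound 1, `c1ccc(N2CCN(CCCCCOc3ccc4c(c3)CCC4)CC2)cc1`, gives 27% in this assay, which lies within the scatter of compound 2. Compound 3, `FC(F)(F)c1cccc(N2CCN(CCCOc3ccc4c(c3)CCC4)CC2)c1`, gives 0%, and the change from fluoro to trifluoromethyl on the aromatic carbon brings a number 19 percentage points lower from compound 2 to compound 3 (beyond the scatter), a modest step beyond the scatter.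

Compound 4, `COc1ccccc1N1CCN(CCCOc2ccc3c(c2)CCC3)CC1`, is the compound not yet measured. It differs from compound 2 in one place: 2-methoxyphenyl in place of 3-fluorophenyl on an amine nitrogen in a ring.

Within the data shown here, only the step from compound 2 to compound 3 bears on this change, since it alters the same aromatic ring on the amine nitrogen; there the step was a number 19 percentage points lower from compound 2 to compound 3 (beyond the scatter). The present change swaps a different group, so that step is a weak guide. A shift of moderate size in either direction would not surprise, with no strong reason to expect one. Compound 4 is therefore expected to give about 22% in this assay, somewhere between 0% and 50%, which means an expected step of a number 3 percentage points higher from compound 2 to compound 4 (within the scatter).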

Compound 4, a percentage reported as inhibition, in the whole organism at one dose (the size of the read-out at that dose, not a potency): 0%
Compound 4: the middle estimate sits 22 percentage points above what was measured, and the stated range covers the measured number.
By their numbers in this assay, from the lowest: compounds 3 and 4 (each within the scatter of the next); then compounds 2 and 1 (each within the scatter of the next).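

In this assay, within the data shown here, 2-methoxyphenyl in place of 3-fluorophenyl on the amine nitrogen in the ring gives a number a number 19 percentage points lower from compound 2 to compound 4 (beyond the scatter), so trifluoromethyl is not the only change to this aromatic ring that comes with a drop; compound 3 gives 0% and compound 4 gives 0%, which lie within the scatter of each other. This single step swaps the fluoro for a methoxy and also changes the place of the group on the aromatic ring, so the two changes cannot be told apart here. Nothing measured among these compounds explains the drop.

As far as these compounds go, whether 3-methoxyphenyl or 2-fluorophenyl would stay close to compound 2 remains open, and these two groups would separate the effect of the group from that of its place. From the compounds shown here alone, what an amine or a carboxylic acid on this aromatic ring would do is also open.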